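A Pyrrolidinyl Replacement at the Double-Bonded Ring Carbon

A few compounds are considered here, and "the series" means these few. Any claim that something is new, unique, unknown or untested is made for them only; others in the source may bear on it.

Of the compounds shown here, three on a shared core have been measured. Compound 1 `CCCc1ccc(NC2=CC(=O)c3nc4n(c3C2=O)[C@H]2OC[C@@H](O)[C@H]2OC4)cc1` gives 4660 nM in a functional assay on MCF7 cells (Homo sapiens) for inhibition, read by sulforhodamine B assay; a higher number here means a weaker inhibitor, a lower number a stronger inhibitor. Compound 2 `O=C1C=C(Nc2ccc(Br)cc2)C(=O)c2c1nc1n2[C@H]2OC[C@@H](O)[C@H]2OC1` gives 2580 nM in this assay. For compound 3 `O=C1C=C(Nc2ccc(C(F)(F)F)cc2)C(=O)c2c1nc1n2[C@H]2OC[C@@H](O)[C@H]2OC1` the value in this assay is a limit, > 4000 nM, so its step from compound 1 is a step that the limit leaves unreadable from compound 1 to compound 3. The step of a 1.8-fold lower number from compound 1 to compound 2 (0.26 log units; within the scatter) lies within the scatter, and the step of an at least 1.5-fold higher number from compound 2 to compound 3 (0.19 log units; that floor lies within the scatter) has only a floor. Compound 2 thus holds the lowest of the two readable numbers, with compound 1 nearest and within the scatter of it.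

Compound 4 `O=C1C=C(N2CCCC2)C(=O)c2c1nc1n2[C@H]2OC[C@@H](O)[C@H]2OC1` differs from compound 2 in one place: pyrrolidin-1-yl in place of (4-bromophenyl)amino on a double-bonded ring carbon. For the measured compounds named here, every measured step so far swaps one substituent for another on the aromatic ring while keeping the (4-bromophenyl)amino framework; none of them removes the aromatic ring or the hydrogen-bond donor, so none bears directly on this change, and the measured steps of a 1.8-fold lower number from compound 1 to compound 2 (0.26 log units; within the scatter) and an at least 1.5-fold higher number from compound 2 to compound 3 (0.19 log units; that floor lies within the scatter) were small or unreadable. Given so large a change in the group itself, the number for compound 4 in this assay is expected to move by a 2.5-fold higher number from compound 2 to compound 4 (0.40 log units; beyond the scatter). The estimate for compound 4 is 6500 nM, with a range from 2000 nM to 20000 nM.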

Compound 4, half-maximal inhibitory concentration: > 16000 nM
Compound 4: a limit, no number; the forecaster's own chance of this, stated with the estimate: 35%; middle value at least 2.4-fold (0.39 log units) from the limit.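

For the compounds shown here, for compound 4 the reading in this assay is a limit and not a number: the limit of > 16000 nM in this assay, at which 1 of the 4 values shown sits. Even so, putting pyrrolidin-1-yl in place of (4-bromophenyl)amino on the double-bonded ring carbon gives an at least 6.2-fold higher number from compound 2 to compound 4 (0.79 log units; beyond the scatter), the first step that is printed as beyond the scatter, whereas the earlier changes on the aromatic ring either stayed within the scatter or could not be read. This change is also of a different kind, as it removes the six-membered aromatic ring and the hydrogen-bond donor together, so compound 4 shows that the position tolerates less than those ring substituents suggested, though this single step cannot assign the loss to either feature.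

From the compounds shown here alone, how far the step extends beyond its floor stays open, and so does the question of which feature carries it. A cyclohexylamino group, which keeps the hydrogen on the nitrogen without the aromatic ring, and a methyl(phenyl)amino group, which keeps the aromatic ring without that hydrogen, would be the groups to separate the two.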